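The source may hold more compounds than are shown below. What is called first, only, known or untested is meant among the compounds shown, and "the series" means these compounds.

Measured in an ADME assay on MT2 cells (Homo sapiens) for cytotoxicity, read by XTT assay, with a stated time of 4 days (on this read-out higher numbers stand for lower toxicity in this test and lower numbers for higher toxicity in this test), so far:
compound 1 `Cc1ccc(NC(=O)C(=O)NC(c2nc(C)c(CCO)s2)C2CCCCN2)cc1F` gives 85000 nM
compound 2 `Cc1nc(C(NC(=O)C(=O)Nc2ccc(Cl)cc2)C2CCCCN2C)sc1CCO` gives 88000 nM
compound 3 `Cc1ccc(NC(=O)C(=O)NC(c2nc(C)c(CCO)s2)C2CCCCN2)c(F)c1` gives > 78800 nM as a limit

Compound 3 stands at the limit of > 78800 nM in this assay, at which 1 of the 3 values shown sits, and so has a limit and no number. Compound 4 `Cc1ccc(NC(=O)C(=O)NC(c2nc(C)c(CO)s2)C2CCCCN2)c(F)c1` carries the change hydroxy in place of hydroxymethyl on a saturated chain carbon bound to an aromatic carbon on the same core, which also reads as 2-hydroxyethyl to hydroxymethyl. Among the measured compounds shown here, the only measured step is a step that the limit leaves unreadable from compound 1 to compound 3 and it concerns another group, so no measured step bears directly on this change. No step beyond the scatter is therefore expected in this assay here. Compound 1, with 85000 nM as a readable number one step from compound 3, sets the expected level. The estimated step is a step that the limit leaves unreadable from compound 3 to compound 4 in this read-out. Compound 4 is expected at 85000 nM with an estimated range from 40000 nM to 160000 nM for now.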

Compound 4, half-maximal cytotoxic concentration: > 109000 nM
Compound 4 ended at the assay's limit (the forecaster's own chance of this, stated with the estimate: 50%); middle value at least 1.2-fold (0.10 log units) away from the limit.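

Among the compounds shown here, compound 3 and compound 4 both stand as limits in this assay, and no step between them can be read. The compounds shown leave open whether 2-hydroxyethyl to hydroxymethyl changes this read-out at all.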